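Swapping the anilino ring on a bromopyrimidine ether series

The source may report more compounds than this note shows. Statements on the series, on what has been measured and on what is new or still open speak of the compounds shown alone.

Measured compounds:
Compound 1, `CNC(=O)c1ccccc1Oc1nc(Nc2ccc(Br)cc2)ncc1Br`, 23500 nM
Compound 2, `CNC(=O)c1ccccc1Oc1nc(Nc2ccccc2F)ncc1Br`, 35500 nM
Compound 3, `CNC(=O)c1ccccc1Oc1nc(Nc2cccc(C(F)(F)F)c2)ncc1Br`, 28300 nM

In a functional assay on A549 cells (Homo sapiens) for antiproliferative activity, read by MTT assay, with a stated time of 24 h (on this read-out higher numbers stand for weaker inhibition and lower numbers for stronger inhibition), compound 2 gives the highest of the three numbers recorded. The step of a 1.5-fold higher number from compound 1 to compound 2 (0.18 log units; within the scatter) is within the scatter, and the value of compound 3 sits close to that of compound 2 as well, so no ordering among the three can be claimed.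

Compound 4, `CNC(=O)c1ccccc1Oc1nc(Nc2cccc(C(C)C)c2)ncc1Br`, is not yet measured. It differs from compound 2 in one place: 3-isopropylphenyl in place of 2-fluorophenyl on a nitrogen on an aromatic ring. For the measured compounds named here, only one measured step bears on a change of the ring on this nitrogen, namely a 1.5-fold higher number from compound 1 to compound 2 (0.18 log units; within the scatter), and that step stayed within the scatter. Compound 3, which carries a 3-(trifluoromethyl)phenyl on the same nitrogen, also gives a value near those of compounds 1 and 2. Nothing among these compounds shows that varying this ring moves this assay beyond the scatter, and no compound with an isopropyl group has been measured.

The expectation for compound 4 is therefore a step of a 1.2-fold lower number from compound 2 to compound 4 (0.07 log units; within the scatter), no larger than the scatter. Compound 4 is estimated at 30000 nM, with a range from 12000 nM to 75000 nM.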

Compound 4, half-maximal inhibitory concentration: 7140 nM
Beside the measured number, compound 4's estimate is 4.2-fold (0.62 log units) above it; measured number below the stated range.
By their numbers in this assay, from the lowest: compound 4; then compounds 1, 3 and 2 (each within the scatter of the next).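

In this assay the ring on this nitrogen proves able to move the number beyond the scatter, which compounds 1, 2 and 3 alone gave no sign of: the step of a 5.0-fold lower number from compound 2 to compound 4 (0.70 log units; beyond the scatter) comes with 3-isopropylphenyl in place of 2-fluorophenyl, and the step of a 3.3-fold lower number from compound 1 to compound 4 (0.52 log units; beyond the scatter) with the same ring in place of 4-bromophenyl. The narrowest comparison is a change of one group alone, isopropyl in place of trifluoromethyl on an aromatic carbon, and the step of a 4.0-fold lower number from compound 3 to compound 4 (0.60 log units; beyond the scatter) shows that this exchange by itself is enough to separate the two compounds. No measurement at hand gives a reason for this difference.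

The compounds shown leave open whether the lower number belongs to isopropyl in particular or would also come with other carbon groups on the ring, such as ethyl, cyclopropyl or tert-butyl, and whether a methoxy group or an amine there would behave alike. They also leave open whether the step holds on the core when its methyl amide or its bromine is replaced, or in other cell lines.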